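The source may report more compounds than this note shows. Statements on the series, on what has been measured and on what is new or still open speak of the compounds shown alone.

Measured compounds:

- compound 1 `CC[C@H](C)[C@H]1C(=O)N[C@H](Cc2cc(Cl)c(O)c(Cl)c2)C(=O)N[C@@H](C(C)C)C(=O)O[C@H](c2ccccc2)[C@H](C)/C=C/C=C(\C)[C@H](OC)C[C@@H]2O[C@@]2(C)C(=O)N1C` gives 4.25 nM
- compound 2 `CC[C@H](C)[C@H]1C(=O)N[C@H](Cc2ccc(O)c(Br)c2)C(=O)N[C@@H](C(C)C)C(=O)O[C@H](c2ccccc2)[C@H](C)/C=C/C=C(\C)[C@H](OC)C[C@@H]2O[C@@]2(C)C(=O)N1C` gives 3.93 nM
- compound 3 `CC[C@H](C)[C@H]1C(=O)N[C@H](Cc2ccc(O)c(Br)c2)C(=O)N[C@@H](C(C)(C)O)C(=O)O[C@H](c2ccccc2)[C@H](C)/C=C/C=C(\C)[C@H](OC)C[C@H]2O[C@]2(C)C(=O)N1C` gives > 200 nM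

Compound 4 `CC[C@H](C)[C@H]1C(=O)N[C@H](Cc2cc(Cl)c(O)c(Cl)c2)C(=O)N[C@@H](C(C)(C)O)C(=O)O[C@H](c2ccccc2)[C@H](C)/C=C/C=C(\C)[C@H](OC)C[C@H]2O[C@]2(C)C(=O)N1C` is not yet measured.

Compound 1 and compound 2 share one core. The change between them is 3,5-dichloro-4-hydroxyphenyl in place of 3-bromo-4-hydroxyphenyl on a saturated chain carbon bound to a saturated ring carbon, and in a functional assay on HCT-116 cells (Homo sapiens) for antiproliferative activity (a higher number here means a weaker inhibitor, a lower number a stronger inhibitor), it reads a 1.1-fold higher number from compound 2 to compound 1 (0.03 log units; within the scatter). So within this pair, 3,5-dichloro-4-hydroxyphenyl in place of 3-bromo-4-hydroxyphenyl leaves the result where it was.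

For compound 3 this assay reports only a limit, > 200 nM, and that limit is the limit of > 200 nM in this assay, at which 1 of the 3 values shown sits. How the core of compound 3 differs from the core of compound 2 is not broken down here.

Compound 4 follows from compound 3 by 3,5-dichloro-4-hydroxyphenyl in place of 3-bromo-4-hydroxyphenyl on a saturated chain carbon bound to a saturated ring carbon, the same change as from compound 2 to compound 1, at the same place. From compound 3 to compound 4 the step in this assay is expected to be a step that the limit leaves unreadable from compound 3 to compound 4, resting on the earlier step of a 1.1-fold higher number from compound 2 to compound 1 (0.03 log units; within the scatter), which stayed within the scatter. Since compound 3 sits at the limit, compound 4 is most likely also reported as a limit.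

Compound 4 is estimated at 400 nM in this assay, expected to fall between 150 nM and 2000 nM.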

Compound 4, half-maximal inhibitory concentration: > 200 nM
Compound 4 was reported as a limit; the forecaster's own chance of this, stated with the estimate: 80%; the middle value is on the limit's open side.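

In this assay, for the compounds shown here, compound 4 stands only as a limit (> 200 nM) and compound 3 is likewise a limit, so no step between compound 3 and compound 4 can be read: the limit of > 200 nM in this assay, at which 2 of the 4 values shown sit.

On these data alone, what 3,5-dichloro-4-hydroxyphenyl in place of 3-bromo-4-hydroxyphenyl does on the core of compound 3 remains open, as does the actual size of either compound's result.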